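This account rests on a few compounds, and the source may have more. Where it says the series, first, only, none or still open, it means among the compounds named here.

The measured compounds:
Compound 1, `Cc1c(F)cccc1CCCCOc1ccc(/C=C/c2cccc3c(CCCC(=O)O)cn(CC(=O)O)c23)cc1`. In a physicochemical assay for permeability, using PAMPA, with a stated time of 4 h, at pH 7.4, tested at 50 uM (on this read-out lower numbers stand for lower permeability and higher numbers for higher permeability), compound 1 gives < 0.05 10^-6 cm/s, which is a limit of the assay rather than a number.
Compound 2, `O=C(O)CCCc1cn(CC(=O)O)c2c(/C=C/c3ccc(OCCCCOc4ccccc4)cc3)cccc12`. In this assay compound 2 gives < 0.05 10^-6 cm/s, also a limit.
Compound 3, `Cc1c(CCCC(=O)O)c2cccc(/C=C/c3ccc(OCCCCc4c(F)ccc(F)c4F)cc3)c2n1CC(=O)O`. In this assay compound 3 gives 2.6 10^-6 cm/s.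

Among the measured compounds shown here, compound 3 thus stands as the only compound with a number in this set; the other two values are limits. For the measured compounds named here, the single step between measured compounds that differ in one place, a step that the two limits leave unreadable from compound 1 to compound 2, runs between two values that both sit at the limit of < 0.05 10^-6 cm/s in this assay, at which 2 of the 3 values shown sit, so its size cannot be read.

Compound 4, `O=C(O)CCCc1cn(CC(=O)O)c2c(/C=C/c3ccc(OCCCCc4c(F)ccc(F)c4F)cc3)cccc12`, differs from compound 3 by hydrogen in place of methyl on an aromatic carbon. Going by the values given here, no measured step covers this change directly. Compound 1, which also carries hydrogen at this carbon, sits at the limit. So does compound 2. Compound 3, with methyl there, gives a number; yet compounds 1 and 2 differ from compound 3 in the chain end as well, so this comparison is only suggestive. A downward step is expected; the step estimated for compound 4 is an 8.7-fold lower number from compound 3 to compound 4 (0.94 log units; beyond the scatter), with a real chance that only a limit is reported. Compound 4 is estimated at 0.3 10^-6 cm/s, between 0.05 10^-6 cm/s and 1.5 10^-6 cm/s.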

Compound 4, apparent permeability: < 0.05 10^-6 cm/s
Compound 4: no number, only a limit (the forecaster's own chance of this, stated with the estimate: 40%); at least 6.0-fold (0.77 log units) between middle value and limit.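

In this assay, among the compounds shown here, hydrogen in place of methyl on the aromatic carbon next to the ring nitrogen gives an at least 52-fold lower number from compound 3 to compound 4 (1.71 log units; beyond the scatter), the first single change in this set whose size can be read. Compound 4 gives < 0.05 10^-6 cm/s, which is a limit of the assay and not a number. With hydrogen at this carbon, all three chain ends shown stop at that limit, and the steps from compound 1 to compound 4 and from compound 2 to compound 4 cannot be read: the limit of < 0.05 10^-6 cm/s in this assay, at which 3 of the 4 values shown sit.

Going by these compounds, whether methyl at this carbon would also bring compound 1 or compound 2 to a number stays open. So does what an ethyl group or a chlorine atom at this carbon, or a methyl ester in place of the carboxymethyl group, would give in this assay.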